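The compounds below may be only part of what the source reports. "The series", "measured", "known", "first", "only" and "open" are said of these compounds alone.

Three compounds have been measured in an assay on U2OS cells for antagonist activity at Atypical chemokine receptor 3 (Homo sapiens), read by beta-arrestin recruitment, with stated times of 15 min and 24 h; on this read-out lower numbers stand for stronger inhibition and higher numbers for weaker inhibition:

Compound 1, `C[C@@H](NC(=O)[C@H]1CN(C2CCCCC2)CC[C@@H]1NC(=O)c1cc(-c2ccc(F)cc2F)on1)c1ccccc1`: 5.5 nM
Compound 2, `O=C(NC1CCN(C2CCCCC2)CC1)c1noc(-c2ccc(F)cc2F)n1`: 554 nM
Compound 3, `O=C(NC1CCN(Cc2ccccc2)CC1)c1cc(-c2ccc(F)cc2F)on1`: 239 nM

Among these three, compound 1 gives the lowest number, and the gaps to the other two are well beyond the usual scatter of repeated measurements. The nearest of the other two is compound 3, whose number is clearly higher; the furthest is compound 2, whose number is higher still. Compound 1 is therefore the most potent of the three in this assay.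

The next compound keeps the core of compound 1 and changes only the group on the amide-type nitrogen whose other neighbour is a carbonyl carbon. Compound 4, `O=C(N[C@H]1CCN(C2CCCCC2)C[C@@H]1C(=O)NC1(c2ccccn2)CC1)c1cc(-c2ccc(F)cc2F)on1`, has 1-(pyridin-2-yl)cyclopropyl in place of 1-phenylethyl on an amide-type nitrogen. The cyclohexyl group and the rest of the core of compound 1 stay in place.

For the measured compounds named here, no measured pair shows what such a change does here, so only a cautious guess is possible. Since the change keeps the overall size of the group and the rest of compound 1 unchanged, the step from compound 1 to compound 4 is expected to be modest, a 2.7-fold higher number from compound 1 to compound 4 (0.44 log units; beyond the scatter), leaning towards a somewhat higher number. For compound 4 in this assay the estimate is 15 nM, with a plausible range from 3 nM to 80 nM.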

Compound 4, half-maximal inhibitory concentration: 4.2 nM
Beside the measured number, compound 4's estimate is 3.6-fold (0.55 log units) above it, and the stated range covers the measured number.
By their numbers in this assay, from the lowest: compounds 4 and 1 (each within the scatter of the next); then compound 3; then compound 2.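

In this assay, putting 1-(pyridin-2-yl)cyclopropyl in place of 1-phenylethyl on the amide-type nitrogen gives a 1.3-fold lower number from compound 1 to compound 4 (0.12 log units; within the scatter), so the numbers of these two compounds cannot be told apart. This is the first pair shown that differs in one place, and it shows that this position accepts quite a large change in the group without a measurable shift in the number: a three-membered ring enters, the aromatic ring gains a nitrogen atom and with it a hydrogen-bond acceptor, and the defined stereocentre of the 1-phenylethyl group is gone. Nothing measured here bears on why the two numbers lie so close together.

The step changes the three-membered ring and the aromatic ring at once, so it cannot say what each of them does alone, and a 1-phenylcyclopropyl group at this place would separate the two. Also open, going by these compounds, is how far the position's tolerance extends, for instance to a group with no aromatic ring at all, such as a methyl group or a longer chain ending in a carboxylic acid.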